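This account rests on a few compounds, and the source may have more. Where it says the series, first, only, none or still open, it means among the compounds named here.

Compound 1 `CCCSc1nc(N)nc2c1ncn2/C=C1/CC1(CO)CO`: > 20000 nM
Compound 2 `Nc1nc(NC2CC2)c2ncn(/C=C3/CC3(CO)CO)c2n1`: 71500 nM

The value recorded for compound 1 is a limit of the assay, not a number (the limit of > 20000 nM in this assay, at which 1 of the 2 values shown sits). In an ADME assay on BCBL1 cells (Homo sapiens) for cytotoxicity, with a stated time of 7 days (a lower number here means that less compound is tolerated, a higher number that more compound is tolerated), compound 2 gives 71500 nM, which is the only number among the two results shown, so compound 2 cannot be placed above or below compound 1. Within the data shown here, the single measured step, a step that the limit leaves unreadable from compound 1 to compound 2, is therefore unreadable and offers no guide to any later change.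

Compound 3 `Nc1nc(NC2CCCC2)c2ncn(/C=C3/CC3(CO)CO)c2n1` differs from compound 2 by cyclopentyl in place of cyclopropyl on a nitrogen on an aromatic ring. Among the measured compounds shown here, no measured step touches this place or this kind of change, so there is nothing in the data that would point to a shift in either direction. The account therefore expects no step beyond the scatter, a 1.0-fold lower number from compound 2 to compound 3 (0.01 log units; within the scatter). For compound 3 in this assay the estimate is 70000 nM, with a range from 30000 nM to 160000 nM.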

Compound 3, half-maximal cytotoxic concentration: 71700 nM
Beside the measured number, compound 3's estimate is 1.0-fold (0.01 log units) below it, within the range that was stated.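

In this assay, the change gives a 1.0-fold higher number from compound 2 to compound 3 (0.00 log units; within the scatter), which is the first readable step among the compounds shown. At this place on the nitrogen, a cyclopentyl ring with 5 heavy atoms and a cyclopropyl ring with 3 heavy atoms therefore cannot be told apart in this read-out. The value recorded for compound 1 is a limit and not a number, so the steps that start from compound 1 cannot be read: the limit of > 20000 nM in this assay, at which 1 of the 3 values shown sits.

The compounds shown leave open whether this insensitivity extends to other groups on the same nitrogen, such as a phenyl ring or a hydroxyethyl chain. They also leave open how the propylsulfanyl group of compound 1 compares in number with cyclopropylamino or cyclopentylamino on the shared core.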